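This account rests on a few compounds, and the source may have more. Where it says the series, first, only, none or still open, it means among the compounds named here.

Compound 1 `O=C(O)Cc1sc(COc2ccc(Cl)cc2)nc1-c1ccc(Cl)cc1`: 32 nM 
Compound 2 `O=C(O)Cc1sc(C(c2ccccc2)c2ccc(Cl)cc2)nc1-c1ccc(F)cc1`: 14 nM 
Compound 3 `NS(=O)(=O)c1cccc(-c2nc(C(c3ccc(F)cc3)c3ccc(F)cc3)sc2CC(=O)O)c1`: 140 nM 

In an in vitro assay on HEK385-7 cells for displacement of a labelled ligand from prostaglandin D2 receptor 2 (Homo sapiens) (on this read-out lower numbers stand for stronger inhibition and higher numbers for weaker inhibition), compound 3 gives the highest number of the three, with compound 1 nearest and compound 2 furthest, both beyond the scatter. Compound 4 `COc1cc(-c2nc(C(c3ccc(F)cc3)c3ccc(F)cc3)sc2CC(=O)O)ccn1` has not been measured in this assay. It differs from compound 3 in one place: 2-methoxypyridin-4-yl in place of 3-sulfamoylphenyl on an aromatic carbon. Among the compounds with values here, compounds 1 and 2, which carry other groups on the same aromatic carbon, both give lower numbers than compound 3, but no step between measured compounds covers this particular change, so the direction rests on that comparison alone. The author expects a modest move toward lower numbers, a 2.0-fold lower number from compound 3 to compound 4 (0.30 log units; within the scatter), at about the edge of the scatter. For compound 4 in this assay the estimate is 70 nM, with a range from 20 nM to 250 nM.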

Compound 4, half-maximal inhibitory concentration: 29 nM
Compound 4: middle estimate off by 2.4-fold (0.38 log units), on the high side; measured number inside the range.
By their numbers in this assay, from the lowest: compound 2; then compounds 4 and 1 (each within the scatter of the next); then compound 3.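

In this assay, 2-methoxypyridin-4-yl in place of 3-sulfamoylphenyl gives a 4.8-fold lower number from compound 3 to compound 4 (0.68 log units; beyond the scatter) with the rest of the molecule unchanged. Within the data shown here, this is the first reading of this aromatic carbon on its own, since compounds 1 and 2 differ from compound 3 in more than one place, and it shows that the group held here can move the number beyond the scatter. Nothing available explains the step.

Still open, from the compounds shown here alone, is which part of the change matters: the ring nitrogen, the methoxy group or the loss of the sulfamoyl group. Also open, going by these compounds, is what a plain phenyl or a 3-methoxyphenyl would give on this carbon.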